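Methyl to fluoro on the outer aromatic ring

A few compounds are considered here, and "the series" means these few. Any claim that something is new, unique, unknown or untested is made for them only; others in the source may bear on it.

Compound 1 `Cc1ccc(-c2nc3sccn3c2/C=N/OCc2ccc(Cl)c(Cl)c2)cc1` gives 490 nM in an assay on HepG2 cells for agonist activity at nuclear receptor subfamily 1 group I member 3 (Homo sapiens), read by a luciferase reporter, with a stated time of 23 h (a lower number here means that less compound is needed, a higher number that more compound is needed for the effect), the highest of the three numbers, though compound 2 `Clc1ccc(-c2nc3occn3c2/C=N/OCc2ccc(Cl)c(Cl)c2)cc1` at 410 nM and compound 3 `Clc1ccc(CO/N=C/c2c(-c3ccc4ccccc4c3)nc3occn23)cc1Cl` at 370 nM both lie within the scatter of it. For the measured compounds named here, the only step between measured compounds, a 1.1-fold lower number from compound 2 to compound 3 (0.04 log units; within the scatter), concerns a different part of the molecule and bears only loosely on the present change. Compound 4 `Fc1ccc(-c2nc3sccn3c2/C=N/OCc2ccc(Cl)c(Cl)c2)cc1` differs from compound 1 by fluoro in place of methyl on an aromatic carbon. Compound 2 carries chloro where compound 1 carries methyl, but also differs in its core, so its value alone cannot be read as a step. Nothing seen so far moves beyond the scatter, so no step beyond it is expected in this assay. Compound 4 is therefore expected to give 500 nM, in the range 250 nM to 1000 nM, an estimated step of a 1.0-fold higher number from compound 1 to compound 4 (0.01 log units; within the scatter).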

Compound 4, half-maximal effective concentration: 670 nM
The estimate for compound 4 lay 1.3-fold (0.13 log units) below the measured number, within the range that was stated.
By their numbers in this assay, from the lowest: compounds 3, 2, 1 and 4 (each within the scatter of the next).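

For the compounds shown here, replacing 4-methylphenyl with 4-fluorophenyl gives a 1.4-fold higher number from compound 1 to compound 4 (0.14 log units; within the scatter) in this assay, the only reading of this position with the core held constant. Within this pair, methyl and fluoro on this aromatic carbon are therefore not separated in this assay. No measured evidence bears on this step.

As far as these compounds go, whether an amine or a carboxylic acid at this position would move the number beyond the scatter remains open. Equally open, from the compounds shown here alone, is whether methyl and fluoro would also read alike on the core of compound 2.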